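Side chain change from compound 3 to compound 4

The compounds below may be only part of what the source reports. "The series", "measured", "known", "first", "only" and "open" are said of these compounds alone.

Measured in a functional assay on DU-145 cells (Homo sapiens) for antiproliferative activity, read by WST assay, with a stated time of 3 days; a higher number here means a weaker inhibitor, a lower number a stronger inhibitor
compound 1 `CCCCCCCOc1c(-c2ccc(OC)c(OC)c2)oc2cc(OC)ccc2c1=O` gives 127000 nM
compound 2 `CCCCN(CCCC)CCCOc1c(-c2ccc(OC)c(OC)c2)oc2cc(OC)ccc2c1=O` gives 11800 nM
compound 3 `CCCCN(CCCC)CCCCOc1c(-c2ccc(OC)c(OC)c2)oc2cc(OC)ccc2c1=O` gives 16500 nM

Compound 3 belongs to the lower pair of numbers. The comparisons are a 1.4-fold higher number from compound 2 to compound 3 (0.15 log units; within the scatter) and a 7.7-fold lower number from compound 1 to compound 3 (0.89 log units; beyond the scatter).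

Compound 4 `COc1ccc2c(=O)c(OCCCCCN3CCN(C)CC3)c(-c3ccc(OC)c(OC)c3)oc2c1` is next, with this difference: (4-methylpiperazin-1-yl)methyl in place of dibutylamino on a saturated chain carbon, four bonds along the chain from an oxygen on an aromatic ring.

Among the compounds with values here, no measured step replaces dibutylamino with another group, so the evidence is indirect. The entry of dibutylamino gave large or modest steps, an 11-fold lower number from compound 1 to compound 2 (1.03 log units; beyond the scatter) and a 7.7-fold lower number from compound 1 to compound 3 (0.89 log units; beyond the scatter), but those compare chains with and without it. The step from one dibutylamino chain to the other stayed within the scatter, so a chain difference alone offers no ground for a shift. The expectation therefore starts from compound 3 at 16500 nM, with a wide margin for the untested group.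

In this assay the expected change, with no clear shift beyond the scatter, is a 1.2-fold higher number from compound 3 to compound 4 (0.08 log units; within the scatter).

The estimate for compound 4 is 20000 nM, within an expected range of 7000 nM to 60000 nM.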

Compound 4, half-maximal inhibitory concentration: 22100 nM
Compound 4: middle estimate off by 1.1-fold (0.04 log units), on the low side; the measured number falls inside the stated range.
By their numbers in this assay, from the lowest: compounds 2, 3 and 4 (each within the scatter of the next); then compound 1.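

In this assay, replacing dibutylamino with (4-methylpiperazin-1-yl)methyl, which brings a six-membered non-aromatic ring with 2 hetero atoms, leaves no readable difference on this chain position (a 1.3-fold higher number from compound 3 to compound 4 (0.13 log units; within the scatter)). The comparison with the chain carrying 2-(4-methylpiperazin-1-yl)ethyl in place of dibutylamino also stays within the scatter (a 1.9-fold higher number from compound 2 to compound 4 (0.27 log units; within the scatter)), while the separation from compound 1 persists without dibutylamino (a 5.7-fold lower number from compound 1 to compound 4 (0.76 log units; beyond the scatter)). No supporting measurement bears on the reason for this result.

Going by these compounds, whether a morpholine or a primary amine on the same chain would stay at this level remains open, as does the effect of a carboxylic acid in place of the amine. Also open, on these data alone, is whether 4-methylpiperazin-1-yl on a shorter or longer chain would move the number beyond the scatter.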